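This account rests on a few compounds, and the source may have more. Where it says the series, first, only, none or still open, it means among the compounds named here.

Compound 1 `COc1nc(=O)n(C)c(CC(F)(COC(C)=O)COC(C)=O)c1C` carries a fluoro group on the chain carbon between two acetate arms. In a functional assay on HeLa cells (Homo sapiens) for antiproliferative activity, read by MTT assay, with a stated time of 72 h (a higher number here means a weaker inhibitor, a lower number a stronger inhibitor), compound 1 gives > 100000 nM, which is a limit of the assay and not a number. Two further compounds share the same core. Compound 2 `COc1nc(=O)n(C)c(CC(O)(COCc2ccccc2)COCc2ccccc2)c1C`, with a hydroxy group and two benzyl ethers, gives 29500 nM in this assay. Compound 3 `COc1nc(=O)n(C)c(CC(O)(CO)CO)c1C`, with the hydroxy group and both acetates stripped away, also returns a limit in this assay, namely > 100000 nM. So compound 1 stands at the limit of > 100000 nM in this assay, at which 2 of the 3 values shown sit, alongside compound 3, and no measured number places it relative to compound 2 beyond the fact that compound 2 lies inside the range of the assay.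

Compound 4 `COc1nc(=O)n(C)c(CC(O)(COC(C)=O)COC(C)=O)c1C` differs from compound 1 by hydroxy in place of fluoro on a saturated chain carbon bound to three saturated chain carbons. Among the compounds with values here, no measured pair isolates this exchange; compound 2 and compound 3 both carry the hydroxy group but differ from compound 4 elsewhere. Because compound 1 gives only a limit of > 100000 nM, the size of the step from compound 1 to compound 4 is expected to be an at least 1.2-fold lower number from compound 1 to compound 4 (0.09 log units; that floor lies within the scatter), with the true direction uncertain and a fair chance that compound 4 again returns a limit. The estimate for compound 4 is 80000 nM, expected to fall between 25000 nM and 250000 nM.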

Compound 4, half-maximal inhibitory concentration: > 100000 nM
Compound 4: a limit, no number (the forecaster's own chance of this, stated with the estimate: 55%); middle value at least 1.2-fold (0.09 log units) from the limit.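

Compound 4, like compound 1, returns a limit and not a number in this assay, so the step between the two cannot be read. The result places compound 4 with the others at the limit: the limit of > 100000 nM in this assay, at which 3 of the 4 values shown sit. The compounds shown leave open whether hydroxy in place of fluoro at this carbon changes antiproliferative activity at all.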